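Carboxylic acid replaces phenyl on a bile acid receptor agonist

The source may hold more compounds than are shown below. What is called first, only, known or untested is meant among the compounds shown, and "the series" means these compounds.

Measured compounds:
compound 1, `Cc1ccccc1-n1nc(C)c2c1NC(=O)[C@H](C)S[C@@H]2c1ccc(-c2ccccc2)cc1`, 990 nM
compound 2, `Cc1ccc(-n2nc(C)c3c2NC(=O)[C@H](C)S[C@@H]3c2ccc(Oc3ccccc3)cc2)cc1`, 3400 nM

In an assay on isolated protein for agonist activity at Bile acid receptor (Homo sapiens), read by AlphaScreen, with a stated time of 30 min (a higher number here means that more compound is needed for the effect, a lower number that less compound is needed), compound 1 gives 990 nM, the lower of the two numbers, while compound 2 gives 3400 nM, a gap beyond the usual scatter. Compound 3, `Cc1ccccc1-n1nc(C)c2c1NC(=O)[C@H](C)S[C@@H]2c1ccc(Oc2ccc(C(=O)O)cc2)cc1`, has not been measured. It differs from compound 1 in one place: 4-carboxyphenoxy in place of phenyl on an aromatic carbon. Within the data shown here, no measured pair shows this exact change, so its size is uncertain. A modest lowering of the number is expected, giving an estimated step of a 2.0-fold lower number from compound 1 to compound 3 (0.30 log units; within the scatter) in this assay. Compound 3 is therefore expected to give about 500 nM, plausibly between 120 nM and 2000 nM.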

Compound 3, half-maximal effective concentration: "not active" (no number reported)
Nothing numeric was reported for compound 3, and the estimate cannot be compared.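

Among these compounds, compound 3 is reported as "not active" without a number, so no step from compound 1 to compound 3 can be read. The compounds shown leave open which part of 4-carboxyphenoxy goes with this result. Nothing available explains it.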